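Swapping 3,4-Dichlorophenyl for 3,4-Dimethoxyphenyl in Compound 1

This account rests on a few compounds, and the source may have more. Where it says the series, first, only, none or still open, it means among the compounds named here.

Compound 1 `Nc1cc(N)c2nc(-c3ccccc3)c(NCc3ccc(Cl)c(Cl)c3)nc2c1`: < 100000 nM
Compound 2 `Nc1cc(N)c2nc(-c3ccccc3)c(Sc3ccc(Cl)c(Cl)c3)nc2c1`: < 100000 nM
Compound 3 `CCOC(=O)[C@H](CCC(=O)O)NC(=O)c1ccc(Oc2nc3cc(N)cc(N)c3nc2-c2ccccc2)cc1`: < 50200 nM

Of the compounds shown here, three built on one shared core have been tested in a functional assay on UO-31 cells (Homo sapiens) for inhibition, read by sulforhodamine B assay, with a stated time of 48 h; a lower number here means a stronger inhibitor of growth, a higher number a weaker inhibitor of growth. Compound 1 gives < 100000 nM, which is a limit of the assay rather than a measured number. Compound 2 likewise gives < 100000 nM, also a limit. Compound 3 gives < 50200 nM, again a limit. Compound 1 thus stands at the limit of < 100000 nM in this assay, at which 2 of the 3 values shown sit, and no ordering among the three can be read from these values.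

Compound 4 `COc1ccc(CNc2nc3cc(N)cc(N)c3nc2-c2ccccc2)cc1OC` has not yet been measured. It differs from compound 1 in one place: 3,4-dimethoxyphenyl in place of 3,4-dichlorophenyl on a saturated chain carbon bound to a nitrogen on an aromatic ring. Among the measured compounds shown here, no pair of measured compounds differs in a single place, so no measured step sizes exist here. The expected step from compound 1 to compound 4 is a step that the limit leaves unreadable from compound 1 to compound 4, with no clear direction. Compound 4 is expected to give about 30000 nM, somewhere between 6000 nM and 100000 nM.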

Compound 4, concentration for total growth inhibition: 45700 nM
Beside the measured number, compound 4's estimate is 1.5-fold (0.18 log units) below it; the measured number falls inside the stated range.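

The step from compound 1 to compound 4 cannot be read, because the value for compound 1 is a limit and not a number: the limit of < 100000 nM in this assay, at which 2 of the 4 values shown sit.

As far as these compounds go, whether 3,4-dimethoxyphenyl in place of 3,4-dichlorophenyl strengthens or weakens growth inhibition stays open.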